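A few compounds are considered here, and "the series" means these few. Any claim that something is new, unique, unknown or untested is made for them only; others in the source may bear on it.

Among the measured compounds shown here, compound 2 `CCNC(=O)C(=O)[C@@H](NC(=O)[C@@H](NC(=O)CCCCC1CCSS1)C(C)C)c1ccccc1` gives 400 nM in an assay on isolated protein for inhibition of Calpain-1 catalytic subunit (Sus scrofa), read by fluorescence; a lower number here means a stronger inhibitor, a higher number a weaker inhibitor; the only other measured compound, compound 1 `CCNC(=O)C(=O)[C@H](CC1CCCCC1)NC(=O)[C@@H](NC(=O)CCCCC1CCSS1)C(C)C`, lies within the scatter of that number, since compound 1 gives 250 nM in this assay. For the measured compounds named here, the single measured step, a 1.6-fold higher number from compound 1 to compound 2 (0.20 log units; within the scatter), exchanged cyclohexylmethyl for phenyl on the saturated chain carbon bound to an amide-type nitrogen and a carbonyl carbon and stayed within the scatter. Compound 3 `CCNC(=O)C(=O)[C@H](CCc1ccccc1)NC(=O)[C@@H](NC(=O)CCCCC1CCSS1)C(C)C` carries phenethyl in place of phenyl on a saturated chain carbon bound to an amide-type nitrogen and a carbonyl carbon. Going by the values given here, no measured step inserts a chain of this kind, so the step from compound 1 to compound 2 is the only guide, and it shows that changing the group at this carbon moved the number little. A shift no larger than the scatter is therefore expected, leaning toward a lower number because compound 1, with its larger group at this carbon, gives 250 nM. The estimated step for compound 3 is a 1.8-fold lower number from compound 2 to compound 3 (0.26 log units; within the scatter). Compound 3 is expected to give about 220 nM, in a range from 70 nM to 700 nM.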

Compound 3, half-maximal inhibitory concentration: > 1000 nM
Compound 3: a limit, no number; the forecaster's own chance of this, stated with the estimate: 3%; at least 4.5-fold (0.65 log units) between middle value and limit.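

In this assay compound 3 stands at a limit of the assay, not at a number: the limit of > 1000 nM in this assay, at which 1 of the 3 values shown sits. The earlier step had left open whether the group on this saturated chain carbon bound to an amide-type nitrogen and a carbonyl carbon mattered at all, since it stayed within the scatter, but phenethyl moves the number beyond it, with an at least 2.5-fold higher number from compound 2 to compound 3 (0.39 log units; beyond the scatter) and an at least 4.0-fold higher number from compound 1 to compound 3 (0.60 log units; beyond the scatter). The carbon therefore does not tolerate every group, and the same six-membered aromatic ring that compound 2 carries is no longer enough once it is held out on the phenethyl chain.

The compounds shown leave open how far compound 3 lies past its limit. They also leave open whether benzyl or cyclohexylethyl at this carbon would stay with compound 1 and compound 2 or go with compound 3.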